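Sulfoxide series: amide substituent swap at the piperidine carbonyl

This account rests on a few compounds, and the source may have more. Where it says the series, first, only, none or still open, it means among the compounds named here.

Compound 1 `O=C(c1ccc(F)cc1)N1CCC(NCCSC(c2ccc(F)cc2)c2ccc(F)cc2)CC1` in an assay on membranes from Cortex for displacement of a labelled ligand from Sigma non-opioid intracellular receptor 1 (Cavia porcellus), read by scintillation counting, with a stated time of 120 min (on this read-out lower numbers stand for stronger inhibition and higher numbers for weaker inhibition), gives 32.1 nM. Compound 2 `CC(C)(C)C(=O)N1CCC(NCC[S+]([O-])C(c2ccc(F)cc2)c2ccc(F)cc2)CC1` gives 11200 nM in this assay and thus stands at the highest of the two numbers, far beyond the scatter from compound 1. Compound 3 `O=C(c1ccc(F)cc1F)N1CCC(NCC[S+]([O-])C(c2ccc(F)cc2)c2ccc(F)cc2)CC1` differs from compound 2 by 2,4-difluorophenyl in place of tert-butyl on a carbonyl carbon. Within the data shown here, no measured step covers this change, yet compound 1, which also bears an aromatic group on that carbonyl carbon, gives 32.1 nM, so a step toward lower numbers beyond the scatter is expected, a 7.5-fold lower number from compound 2 to compound 3 (0.87 log units; beyond the scatter). Compound 3 is estimated at 1500 nM, within 300 nM to 8000 nM.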

Compound 3, inhibition constant: 171 nM
For compound 3 the middle estimate is 8.8-fold (0.94 log units) above the measured one; measured number outside the range, below it.
By their numbers in this assay, from the lowest: compound 1; then compound 3; then compound 2.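

With the sulfoxide held constant, the group on the carbonyl carbon alone moves the number strongly in this assay: 2,4-difluorophenyl in place of tert-butyl gives a 65-fold lower number from compound 2 to compound 3 (1.82 log units; beyond the scatter). This position is therefore sensitive to the swap, and a low number in this sulfoxide pair goes with the aromatic group. No evidence at hand bears on the cause of this step.

Open, going by these compounds, is whether cyclohexyl or unsubstituted phenyl on this carbonyl carbon would sit nearer compound 3 or compound 2. That comparison would separate the contribution of the aromatic ring from that of its fluorines.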